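Adenosine uronamides at the 2-oxoglutarate receptor

A few compounds are considered here, and "the series" means these few. Any claim that something is new, unique, unknown or untested is made for them only; others in the source may bear on it.

Measured so far:
compound 1 `CCCCNC(=O)[C@H]1OC(n2cnc3c(N)ncnc32)[C@H](O)[C@@H]1O`, 17 nM
compound 2 `C[C@H]1CC[C@@H](NC(=O)[C@H]2O[C@@H](n3cnc4c(N)ncnc43)[C@H](O)[C@@H]2O)CC1`, 55.6 nM

Both compounds carry the same core and differ in the group on the amide-type nitrogen. In an assay on cell membranes for binding affinity to 2-oxoglutarate receptor 1 (Rattus norvegicus), read by radioligand binding (a lower number here means a stronger inhibitor, a higher number a weaker inhibitor), compound 1 gives 17 nM, the lowest of the two numbers. In this assay compound 2 gives 55.6 nM, a higher number that lies beyond the scatter of the measurement, so compound 1 stands as the stronger of the two.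

The next compound, compound 3 `CCONC(=O)[C@H]1OC(n2cnc3c(N)ncnc32)[C@H](O)[C@@H]1O`, has not been measured in this assay yet. It differs from compound 1 in one place: ethoxy in place of butyl on an amide-type nitrogen. No comparable exchange has been measured among the compounds in hand, so the size of the step is open. Among the measured compounds shown here, the only guide is that compound 2, with a different group at the same nitrogen, gives 55.6 nM, a weaker result than compound 1. A moderate loss is expected from compound 1 to compound 3, a 3.5-fold higher number from compound 1 to compound 3 (0.55 log units; beyond the scatter). For compound 3 the estimate in this assay is 60 nM, within a range from 15 nM to 300 nM.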

Compound 3, inhibition constant: 67 nM
Estimate against measurement, compound 3: 1.1-fold (0.05 log units) below, within the range that was stated.
By their numbers in this assay, from the lowest: compound 1; then compounds 2 and 3 (each within the scatter of the next).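

In this assay, among the compounds shown here, ethoxy in place of butyl on the amide-type nitrogen gives a 3.9-fold higher number from compound 1 to compound 3 (0.60 log units; beyond the scatter) and provides the only single-change step at this position so far, a modest loss that lies beyond the scatter. The exchange replaces an all-carbon chain with one that carries an oxygen and a hydrogen-bond acceptor, and compound 3 still gives 67 nM so this position accepts that change with only a modest loss in this assay. No measurement at hand speaks to what lies behind the step.

From the compounds shown here alone, a single step cannot separate the effect of the oxygen from that of having fewer carbons in the group, so it remains open whether ethyl, which has the same carbon count as ethoxy but no oxygen, or butoxy, which keeps the oxygen on a longer chain, would give a value closer to that of compound 1 or compound 3. Also open, going by these compounds, is how this nitrogen would respond to a chain ending in an amine or a carboxylic acid.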